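A few compounds are considered here, and "the series" means these few. Any claim that something is new, unique, unknown or untested is made for them only; others in the source may bear on it.

Working notes on the series.

Compound 1 `C[C@@H](NCC1CCN(CCCc2c[nH]c3ccc(-n4cnnc4)cc23)CC1)c1ccccc1` is the reference point. In an assay on CHO cells for displacement of a labelled ligand from 5-hydroxytryptamine receptor 1B (Homo sapiens) (on this read-out higher numbers stand for weaker inhibition and lower numbers for stronger inhibition), compound 1 gives 14 nM; among the two numbers measured it is the higher, and the nearest neighbour, compound 2 `CC(=O)Nc1ccc([C@H](C)NCC2CCN(CCCc3c[nH]c4ccc(-n5cnnc5)cc34)CC2)cc1`, gives 9.3 nM in this assay, so that the step of a 1.5-fold lower number from compound 1 to compound 2 (0.18 log units; within the scatter) stays within the scatter.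

Compound 3 `c1cc(CNC2CCN(CCCc3c[nH]c4ccc(-n5cnnc5)cc34)CC2)co1` has not been measured. It differs from compound 1 in one place: ((furan-3-yl)methyl)amino in place of ((1-phenylethyl)amino)methyl on a saturated ring carbon. Going by the values given here, the only measured step, from compound 1 to compound 2, alters the 1-phenylethyl group by an acetamido substituent and leaves the amine and its attachment to the saturated ring untouched; it does not bear on the present change, which removes the 1-phenylethyl group altogether, shortens the link by one carbon and shifts the amine onto the ring carbon. Among the compounds with values here, no measured step covers this, so the direction is uncertain; a weaker number is expected, with a wide range, and a 3.2-fold higher number from compound 1 to compound 3 (0.51 log units; beyond the scatter) is the estimated step. For compound 3 the estimate in this assay is 45 nM, between 8 nM and 250 nM.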

Compound 3, half-maximal inhibitory concentration: 78 nM
Compound 3: middle estimate off by 1.7-fold (0.24 log units), on the low side, within the range that was stated.
By their numbers in this assay, from the lowest: compounds 2 and 1 (each within the scatter of the next); then compound 3.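

In this assay, going by these compounds alone, ((furan-3-yl)methyl)amino in place of ((1-phenylethyl)amino)methyl on the saturated ring carbon gives a 5.6-fold higher number from compound 1 to compound 3 (0.75 log units; beyond the scatter), the first step beyond the scatter. The position therefore responds to replacement of the whole side group, whereas adding an acetamido substituent to the 1-phenylethyl group gave only a 1.5-fold lower number from compound 1 to compound 2 (0.18 log units; within the scatter). No measured property is available to account for the weaker number.

As far as these compounds go, this one step combines a change of aromatic ring, the loss of the defined stereocentre and a change in how the amine is attached, and the share of each remains open. From the compounds shown here alone, it is also open whether a benzylamino group in place of ((furan-3-yl)methyl)amino would keep the number of compound 3 or move it towards that of compound 1.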